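The source may report more compounds than this note shows. Statements on the series, on what has been measured and on what is new or still open speak of the compounds shown alone.

Measured so far:
- compound 1 `COc1ccc(/C=C2/S/C(=N/c3ccccc3)N(Cc3ccncc3)C2=O)cc1`: 47900 nM
- compound 2 `O=C1/C(=C\c2ccc(Cl)cc2)S/C(=N/c2ccccc2)N1Cc1ccncc1`: 42300 nM
- compound 3 `CCOc1cc(/C=C2/S/C(=N/c3ccccc3)N(Cc3ccncc3)C2=O)ccc1O`: 46500 nM

In an ADME assay on HEK293 cells (Homo sapiens) for cytotoxicity, read by MTT assay, with a stated time of 48 h (a higher number here means a weaker inhibitor, a lower number a stronger inhibitor), compound 3 stands level with the other two compounds, since a 1.0-fold lower number from compound 1 to compound 3 (0.01 log units; within the scatter) and a 1.1-fold higher number from compound 2 to compound 3 (0.04 log units; within the scatter) both lie within the scatter. The next compound, compound 4 `Cc1ccc(/C=C2/S/C(=N/c3ccccc3)N(Cc3ccncc3)C2=O)s1`, changes the group on the double-bonded chain carbon bound to a double-bonded ring carbon: 5-methylthiophen-2-yl in place of 3-ethoxy-4-hydroxyphenyl on a double-bonded chain carbon bound to a double-bonded ring carbon.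

Two measured steps change that same place, the two just given, and neither moves the number beyond the scatter. The remaining step, a 1.1-fold lower number from compound 1 to compound 2 (0.05 log units; within the scatter), is just as small. On these data alone, none of these steps brings in a five-membered aromatic ring, so the new group itself remains untested, and the range must stay wide. On this evidence, no change beyond the scatter is expected in this assay, and the expected step is a 1.0-fold lower number from compound 3 to compound 4 (0.01 log units; within the scatter). For compound 4, the estimated value is 45000 nM, with an expected range from 25000 nM to 80000 nM.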

Compound 4, half-maximal inhibitory concentration: 146000 nM
For compound 4 the middle estimate is 3.2-fold (0.51 log units) below the measured one, and the stated range ends below it.
By their numbers in this assay, from the lowest: compounds 2, 3 and 1 (each within the scatter of the next); then compound 4.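

In this assay, the group on the double-bonded chain carbon bound to a double-bonded ring carbon proves able to move the number: the 4-methoxyphenyl, 4-chlorophenyl and 3-ethoxy-4-hydroxyphenyl compounds lie within the scatter of one another, whereas 5-methylthiophen-2-yl gives a 3.1-fold higher number from compound 3 to compound 4 (0.50 log units; beyond the scatter), a 3.5-fold higher number from compound 2 to compound 4 (0.54 log units; beyond the scatter) and a 3.0-fold higher number from compound 1 to compound 4 (0.48 log units; beyond the scatter). Going by these compounds alone, the three substituted phenyl groups therefore do not show the full sensitivity of this place, and the first step beyond the scatter arrives with a five-membered aromatic ring carrying one hetero atom in place of a six-membered aromatic ring of carbon only. Nothing measured here accounts for this step.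

The compounds shown leave open whether the step belongs to the five-membered ring or to its methyl group, which thiophen-2-yl without the methyl could separate. On these data alone, whether furan-2-yl, with oxygen as the hetero atom, behaves in the same way also remains open.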